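Compound 2 without its ((thiophen-2-yl)sulfonyl)amino group

The compounds below may be only part of what the source reports. "The series", "measured", "known", "first", "only" and "open" are said of these compounds alone.

In a functional assay for binding affinity, with Homo sapiens as the target, read by fluorescence and flow cytometry (a higher number here means weaker binding, a lower number tighter binding), compound 1 `O=C(NCc1ccccc1)N[C@@H](CNC(=O)c1cc2cc(CCC3CCNCC3)sc2s1)C(=O)O` gives 94 nM, while compound 2 `O=C(NC[C@H](NS(=O)(=O)c1cccs1)C(=O)O)c1cc2sc(CCC3CCNCC3)cc2s1` gives 0.092 nM, the lower of the two numbers and well beyond the scatter. Compound 3 `O=C(O)CCNC(=O)c1cc2sc(CCC3CCNCC3)cc2s1` departs from compound 2 in one place: hydrogen in place of ((thiophen-2-yl)sulfonyl)amino on a saturated chain carbon bound to a carbonyl carbon and a saturated chain carbon, with hydrogen in place of ((thiophen-2-yl)sulfonyl)amino on a saturated chain carbon bound to a carbonyl carbon and a saturated chain carbon. Going by the values given here, no measured pair shows this change alone, so the expectation is uncertain. Weaker binding, beyond the scatter, is expected, with an estimated change of a 220-fold higher number from compound 2 to compound 3 (2.34 log units; beyond the scatter). Compound 3 is estimated at 20 nM, within an expected range of 2 nM to 200 nM.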

Compound 3, dissociation constant: about 600 nM
The estimate for compound 3 lay 30-fold (1.48 log units) below the measured number; the whole stated range lies below it.
By their numbers in this assay, from the lowest: compound 2; then compound 1; then compound 3.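

In this assay, putting hydrogen in place of ((thiophen-2-yl)sulfonyl)amino on this saturated chain carbon gives a 6500-fold higher number from compound 2 to compound 3 (3.81 log units; beyond the scatter). Going by these compounds alone, this is the first measured change at a single place, and it shows that binding depends heavily on what sits at this position. The compounds shown offer no measurement that explains the size of this step. On these data alone, it remains open how much of the step belongs to the nitrogen and how much to the sulfonyl and thiophene parts; a plain amine at this position, or a phenylsulfonylamino group, would help divide it.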